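The source may report more compounds than this note shows. Statements on the series, on what has been measured and on what is new or still open speak of the compounds shown alone.

Working notes on the series, read in a functional assay on BGC-823 cells (Homo sapiens) for inhibition, read by MTT assay, with a stated time of 72 h; a lower number here means a stronger inhibitor, a higher number a weaker inhibitor. Compound 1 `Cc1cc(N2CC[C@@H](C)[C@@H](N(C)c3ncnc4[nH]ccc34)C2)n2ncnc2n1` gives 67400 nM. Compound 2 `Cc1cc(N2CC[C@@H](C)[C@@H](N(C)c3ncnc4[nH]ccc34)C2)n2nc(SCc3nc4ccccc4[nH]3)nc2n1` gives > 100000 nM, which is a limit of the assay and not a number. For the measured compounds named here, compound 3 `Cc1cc(N2CC[C@@H](C)[C@@H](N(C)c3ncnc4[nH]ccc34)C2)n2nc(SCCc3ccccc3)nc2n1` gives 28000 nM, the lowest number so far, with steps to both other compounds beyond the scatter.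

Compound 4 `Cc1ccc(CSc2nc3nc(C)cc(N4CC[C@@H](C)[C@@H](N(C)c5ncnc6[nH]ccc56)C4)n3n2)cc1` is next, and the change is 4-methylphenyl in place of benzyl on a saturated chain carbon bound to a sulfur, or phenethylsulfanyl to (4-methylbenzyl)sulfanyl.

The nearest measured precedent is an at least 3.5-fold lower number from compound 2 to compound 3 (0.55 log units; beyond the scatter), a change at this same place, though one end of it rests on (the limit of > 100000 nM in this assay, at which 1 of the 3 values shown sits). Also relevant is a 2.4-fold lower number from compound 1 to compound 3 (0.38 log units; beyond the scatter), a modest gain from adding the phenethylsulfanyl group. The other addition gives an at least 1.4-fold higher number from compound 1 to compound 2 (0.17 log units; that floor lies within the scatter). Going by the values given here, with only three compounds, this place appears responsive, but neither step matches the present exchange, which keeps a carbon-only aromatic ring, so no shift beyond the scatter is expected.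

The estimated step is a 1.3-fold higher number from compound 3 to compound 4 (0.10 log units; within the scatter). The estimated value for compound 4 is 35000 nM, with an expected range of 12000 nM to 95000 nM.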

Compound 4, half-maximal inhibitory concentration: 69500 nM
Estimate against measurement, compound 4: 2.0-fold (0.30 log units) below; measured number inside the range.
By their numbers in this assay, from the lowest: compound 3; then compounds 1 and 4 (each within the scatter of the next). At a limit, above all of these: compound 2.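

At this place, on a saturated chain carbon bound to a sulfur, 4-methylphenyl in place of benzyl gives a 2.5-fold higher number from compound 3 to compound 4 (0.39 log units; beyond the scatter), so the same atoms joined differently, with one carbon-only aromatic ring on each side, already separate two compounds beyond the scatter. Phenethylsulfanyl is therefore the only group shown here with a gain over hydrogen, while (4-methylbenzyl)sulfanyl gives a 1.0-fold higher number from compound 1 to compound 4 (0.01 log units; within the scatter). The comparison with the benzimidazole-bearing compound reads only as an at least 1.4-fold lower number from compound 2 to compound 4 (0.15 log units; that floor lies within the scatter), and the number for compound 2 is a limit of the assay: the limit of > 100000 nM in this assay, at which 1 of the 4 values shown sits.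

On these data alone, what stays open is whether the chain length or the ring methyl carries the step from phenethylsulfanyl, which a plain benzylsulfanyl group would separate. Also open, as far as these compounds go, is whether a longer chain, such as phenylpropylsulfanyl, gives a lower number than compound 3.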